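Fluorine Added Beside Chlorine on the Aryl Ring

The compounds below may be only part of what the source reports. "The series", "measured", "known", "first", "only" and "open" are said of these compounds alone.

Measured so far:
compound 1, `C[C@H](c1ccc(C(=O)NCCC(=O)O)cc1)N1C(=O)C(c2cccc(Cl)c2)=N[C@]12CC[C@@H](C(C)(C)C)CC2`: 3300 nM
compound 2, `C[C@H](c1ccc(C(=O)NCCC(=O)O)cc1)N1C(=O)C(c2cccc(OC(F)(F)F)c2)=N[C@]12CC[C@@H](C(C)(C)C)CC2`: 1500 nM

In an assay on membranes from liver for displacement of a labelled ligand from Glucagon receptor (Mus musculus), read by scintillation counting, with a stated time of 60 min (a lower number here means a stronger inhibitor, a higher number a weaker inhibitor), compound 2 gives 1500 nM, the lowest of the two numbers, while compound 1 gives 3300 nM. For the measured compounds named here, the one step measured is a 2.2-fold lower number from compound 1 to compound 2 (0.34 log units; beyond the scatter), a modest change that lies beyond the scatter. Compound 3, `C[C@H](c1ccc(C(=O)NCCC(=O)O)cc1)N1C(=O)C(c2cccc(Cl)c2F)=N[C@]12CC[C@@H](C(C)(C)C)CC2`, carries 3-chloro-2-fluorophenyl in place of 3-(trifluoromethoxy)phenyl on a carbon with a double bond to nitrogen. Going by the values given here, the change returns to the chloro substituent of compound 1 and adds a fluorine on the same ring; no measured step tells what that fluorine does by itself. The step from compound 1 to compound 2 therefore bears on it in reverse, and compound 3 is expected to land closer to compound 1 than to compound 2, giving an expected step of a 1.7-fold higher number from compound 2 to compound 3 (0.22 log units; within the scatter) in this assay, likely within the scatter. The estimate for compound 3 is 2500 nM, in the range 800 nM to 8000 nM.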

Compound 3, half-maximal inhibitory concentration: 4000 nM
Compound 3: middle estimate off by 1.6-fold (0.20 log units), on the low side; the range from low to high includes it.
By their numbers in this assay, from the lowest: compound 2; then compounds 1 and 3 (each within the scatter of the next).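

In this assay, fluoro in place of hydrogen on an aromatic carbon of the 3-chlorophenyl group gives a 1.2-fold higher number from compound 1 to compound 3 (0.08 log units; within the scatter), so this added fluorine leaves compound 3 and compound 1 within the scatter of each other. With 3-chloro-2-fluorophenyl in place of 3-(trifluoromethoxy)phenyl, the result is a 2.7-fold higher number from compound 2 to compound 3 (0.43 log units; beyond the scatter), so at this position the added fluorine does not match the lower number seen with the 3-(trifluoromethoxy)phenyl group. Nothing measured here accounts for either step.

From the compounds shown here alone, whether the same fluorine would leave the number unmoved on the 3-(trifluoromethoxy)phenyl group remains open. So does whether a nitrile, a methoxy group or an amine on this aromatic ring would bring the number lower than that of compound 2 at 1500 nM.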